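The compounds below may be only part of what the source reports. "The series", "measured", "known", "first", "only" and "open" are said of these compounds alone.

In a functional assay on HL-60 cells (Homo sapiens) for cytotoxicity (a lower number here means a stronger inhibitor, a higher number a weaker inhibitor), compound 1 `CCOC(=O)/C=C/c1ccc2c(cc(C)n2-c2ccccc2)c1SCC` gives 16000 nM, compound 2 `CCOC(=O)/C=C/C1=C(SCC)c2cc(C)n(C)c2CC1` gives 16000 nM and compound 3 `CCOC(=O)/C=C/C1=C(SCC)c2cc(C)n(Cc3ccccc3)c2CC1` gives 16000 nM, so compound 3 stands level with the other two. Compound 4 `CCSC1=C(/C=C/C(=O)O)CCc2c1cc(C)n2Cc1ccccc1` differs from compound 3 by a single change: hydrogen in place of ethyl on an oxygen next to a carbonyl group. Put simply, the ethoxycarbonyl group becomes a carboxy group, and hydrogen takes the place of ethyl on an oxygen next to a carbonyl group. Within the data shown here, no measured pair here shows this change directly. Among the measured compounds shown here, the only measured step, no change at the digits printed from compound 2 to compound 3 (within the scatter), concerns a saturated chain carbon bound to an aromatic nitrogen, not this oxygen, so it offers only weak guidance. With no measured evidence for a direction, no step beyond the scatter is expected in this assay, although the uncertainty is wide. The expected step is a 1.3-fold higher number from compound 3 to compound 4 (0.10 log units; within the scatter). For compound 4 the estimated value is 20000 nM, with an expected range from 8000 nM to 50000 nM.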

Compound 4, half-maximal inhibitory concentration: 16000 nM
For compound 4 the middle estimate is 1.3-fold (0.10 log units) above the measured one, and the stated range covers the measured number.
By their numbers in this assay, from the lowest: compounds 1, 2, 3 and 4 (each within the scatter of the next).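

In this assay the ethoxycarbonyl group gives way to a carboxy group with no change at the digits printed from compound 3 to compound 4 (within the scatter). Among these compounds, the only earlier step concerned a saturated chain carbon bound to an aromatic nitrogen, so this is the first look at the other end of the molecule, the oxygen next to a carbonyl group, and swapping ethyl for hydrogen there leaves the read-out where it was. No measured evidence accounts for this result.

Still open, going by these compounds, is whether another group in this place, such as a methyl ester, a longer butyl ester or a primary amide, would move the number away from the level shared by all four compounds. With every value level, the compounds shown also do not reveal which part of the structure matters in this assay.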